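Swapping the Amide Substituent in Compound 2

A few compounds are considered here, and "the series" means these few. Any claim that something is new, unique, unknown or untested is made for them only; others in the source may bear on it.

In a physicochemical assay for lipophilicity (on this read-out lower numbers stand for lower lipophilicity and higher numbers for higher lipophilicity), two compounds have been measured. Compound 1 `CNC(=O)c1cc(C(=O)N[C@H]2CC[C@H](O)CC2)c([C@@H](C)c2cccc(C)c2)o1` gives 3.3, and compound 2 `CNC(=O)c1cc(C(=O)NC2CCOCC2)n([C@@H](C)c2ccccc2)n1` gives 3.6. Compound 2 holds the higher of the two numbers, but the gap to compound 1 is within the usual scatter of the measurement, so the two cannot be told apart on this read-out.

The next compound, compound 3 `CNC(=O)c1cc(C(=O)NC2CC2)n([C@@H](C)c2ccccc2)n1`, differs from compound 2 in a single place: cyclopropyl in place of oxan-4-yl on an amide-type nitrogen. Going by the values given here, no step between two measured compounds shows what such a replacement does, so the size of the step from compound 2 to compound 3 rests on the structural change alone.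

The author expects this step to move the number upward by somewhat more than the scatter, meaning an estimated step from compound 2 to compound 3 of a number 0.40 log units higher from compound 2 to compound 3 (beyond the scatter). Compound 3 is therefore expected to give about 4 in this assay, with a likely range from 3.5 to 4.5.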

Compound 3, distribution coefficient: 3.6
Compound 3: the middle estimate sits 0.40 log units above what was measured; the range from low to high includes it.
By their numbers in this assay, from the lowest: compounds 1, 2 and 3 (each within the scatter of the next).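

In this assay, going by these compounds alone, cyclopropyl in place of oxan-4-yl on an amide-type nitrogen gives no change at the digits printed from compound 2 to compound 3 (within the scatter), and this is the only step at this position that can be read so far. It shows that the group on this nitrogen can go from a six-membered non-aromatic ring with 6 heavy atoms and 1 hydrogen-bond acceptor to a three-membered ring of carbon only, with 3 heavy atoms and 0 hydrogen-bond acceptors, while the read-out does not separate compound 2 from compound 3. Nothing measured on these compounds accounts for this result.

One step on one core cannot show whether the same holds for other groups on this nitrogen, such as a longer chain like n-butyl, a ring bearing an amine like piperidin-4-yl, or a chain ending in a carboxylic acid. Compound 1 differs from compound 2 and compound 3 in more than one place, so it cannot show whether this replacement would give the same result on another core.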